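Replacing the Sulfonyl Link with a Naphthyl Group

The compounds below may be only part of what the source reports. "The series", "measured", "known", "first", "only" and "open" are said of these compounds alone.

Of the compounds shown here, three sharing one core have been tested in a functional assay on CHO.K1 cells for antagonist activity at prostaglandin D2 receptor 2 (Homo sapiens), read by GTPgammaS binding, with a stated time of 1 h; on this read-out lower numbers stand for stronger inhibition and higher numbers for weaker inhibition. Compound 1 `CNC(=O)c1cccc(S(=O)(=O)c2ccccc2Cc2c3c(n(CC(=O)O)c2C)CCNC3=O)c1` gives 240 nM. Compound 2 `Cc1c(Cc2ccccc2S(=O)(=O)c2ccc(F)cc2)c2c(n1CC(=O)O)CCNC2=O` gives 3.3 nM. Compound 3 `Cc1c(Cc2ccccc2S(=O)(=O)N(C)Cc2ccccc2)c2c(n1CC(=O)O)CCNC2=O` gives 26 nM. Compound 2 thus has the lowest number of the three: the step of a 7.9-fold higher number from compound 2 to compound 3 (0.90 log units; beyond the scatter) and the step of a 73-fold lower number from compound 1 to compound 2 (1.86 log units; beyond the scatter) are both beyond the scatter, so compound 2 is the most potent of the set.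

Compound 4 `Cc1c(Cc2ccccc2-c2cccc3ccccc23)c2c(n1CC(=O)O)CCNC2=O` has not yet been measured. Relative to compound 2 it carries naphthalen-1-yl in place of (4-fluorophenyl)sulfonyl on an aromatic carbon. The measured steps all alter only the group attached to the sulfonyl sulfur, and they show that this part of the molecule is sensitive: a 73-fold lower number from compound 1 to compound 2 (1.86 log units; beyond the scatter) is large and a 7.9-fold higher number from compound 2 to compound 3 (0.90 log units; beyond the scatter) is modest, both beyond the scatter. Going by the values given here, no measured step removes the sulfonyl itself, so the present change goes further than anything seen. Because the group on this side swung the result in a 73-fold lower number from compound 1 to compound 2 (1.86 log units; beyond the scatter) and a 7.9-fold higher number from compound 2 to compound 3 (0.90 log units; beyond the scatter), a modest to large rise in the number, meaning weaker inhibition, is expected for compound 4, though the direction is uncertain. Compound 4 is estimated at 30 nM in this assay, with a likely range of 5 nM to 300 nM, an expected step of a 9.1-fold higher number from compound 2 to compound 4 (0.96 log units; beyond the scatter).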

Compound 4, half-maximal inhibitory concentration: 480 nM
Compound 4: the middle estimate sits 16-fold (1.20 log units) below what was measured; measured number above the stated range.
By their numbers in this assay, from the lowest: compound 2; then compound 3; then compounds 1 and 4 (each within the scatter of the next).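

Removing the sulfonyl altogether weakens inhibition in this assay sharply (a 150-fold higher number from compound 2 to compound 4 (2.16 log units; beyond the scatter)), a change comparable in size to the largest step seen when only the group on the sulfur was altered (a 73-fold lower number from compound 1 to compound 2 (1.86 log units; beyond the scatter)). So this position tolerates more than a change of the end group alone can reveal: the sulfonyl-linked compound 2 and the directly attached compound 4 stand far apart even though the leaving (4-fluorophenyl)sulfonyl and the entering naphthalen-1-yl have the same count of heavy atoms, which shows that matching that count does not preserve inhibition here. The exchange also takes the count of hydrogen-bond acceptors in this group from 2 to 0, but nothing measured here links that or any other difference to the loss, and no supporting evidence is available to explain it.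

Because the link and the aromatic group change together, the compounds shown cannot tell whether the loss follows from removing the sulfonyl or from introducing naphthalen-1-yl. A 4-fluorophenyl joined directly to the ring, or a carbonyl link carrying 4-fluorophenyl in place of the sulfonyl, would pull these two changes apart.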